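Extending the sulfanyl chain of compound 3 with a hydroxylated chain

The compounds below may be only part of what the source reports. "The series", "measured", "known", "first", "only" and "open" are said of these compounds alone.

Measured compounds and their numbers in a functional assay on HT cells (Homo sapiens) for antiproliferative activity, read by fluorescence, with a stated time of 72 h; a higher number here means a weaker inhibitor of growth, a lower number a stronger inhibitor of growth:
compound 1, `CC(C)c1n[nH]c2c(NCc3ccc(-c4ccccn4)cc3)nc(SCCC(N)=O)nc12`, gives 120 nM
compound 2, `CC(C)c1n[nH]c2c(NCc3ccc(-c4ccccn4)cc3)nc(SCC(O)CN)nc12`, gives 55 nM
compound 3, `CSc1nc(NCc2ccc(-c3ccccn3)cc2)c2[nH]nc(C(C)C)c2n1`, gives 783 nM

Compound 3 stands at the highest number of the three in this assay; its nearest neighbour is compound 1, and compound 2 lies furthest from it. The unmeasured compound 4, `CCC(O)CSc1nc(NCc2ccc(-c3ccccn3)cc2)c2[nH]nc(C(C)C)c2n1`, differs from compound 3 by 1-hydroxypropyl in place of hydrogen on a saturated chain carbon bound to a sulfur. Within the data shown here, two measured steps bear on this change, each running in the opposite direction: a 14-fold higher number from compound 2 to compound 3 (1.15 log units; beyond the scatter) and a 6.5-fold higher number from compound 1 to compound 3 (0.81 log units; beyond the scatter). Both show that removing a chain from the saturated chain carbon bound to a sulfur raises the number, and the chain carrying a hydroxyl and an amine did so most. The 1-hydroxypropyl of compound 4 brings back a chain with a hydroxyl but without the amine or the amide of the measured chains, so a lower number is expected for compound 4 in this assay, with a 7.1-fold lower number from compound 3 to compound 4 (0.85 log units; beyond the scatter) expected to fall between the two measured steps. Compound 4 is therefore estimated at 110 nM, within 40 nM to 300 nM.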

Compound 4, concentration for 50% growth inhibition: 273 nM
For compound 4 the middle estimate is 2.5-fold (0.39 log units) below the measured one, within the range that was stated.
By their numbers in this assay, from the lowest: compound 2; then compound 1; then compound 4; then compound 3.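

In this assay, a chain with a hydroxyl but with neither amine nor amide still lowers the number on its own (a 2.9-fold lower number from compound 3 to compound 4 (0.46 log units; beyond the scatter)), so the gain at this position does not depend on either of those groups. Among these compounds, the amine does add to it: methyl in place of amino, the one change separating these two chains, costs more than the hydroxylated chain gained (a 5.0-fold higher number from compound 2 to compound 4 (0.70 log units; beyond the scatter)). The amide chain also stands ahead of the 1-hydroxypropyl (a 2.3-fold higher number from compound 1 to compound 4 (0.36 log units; beyond the scatter)), so the hydroxylated chain recovers only part of what the two longer-known chains reach.

Open, going by these compounds, is what a plain butyl chain on the sulfur would give in place of the 2-hydroxybutyl, and whether a 3-aminopropyl chain would hold the gain of compound 2 without its hydroxyl. A carboxylic acid at the chain end is equally open, and no measurement shown gives a reason for any of these differences.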